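Dimethylimidazolyl in place of thiazolylamino on the shared core

This account rests on a few compounds, and the source may have more. Where it says the series, first, only, none or still open, it means among the compounds named here.

Compound 1 `CC(C)C(Nc1nccs1)c1ccc(-c2ccc3cccc(F)c3c2)[nH]c1=O` stands lowest of the two numbers in an ADME assay on microsomes from liver (Homo sapiens) for metabolic stability (a higher number here means that the compound lasts longer, a lower number that the compound disappears faster), giving 0.17 h. Compound 2 `CC(C)[C@H](C[C@H]1CCNC1=O)c1ccc(-c2ccc3cccc(F)c3c2)[nH]c1=O` gives 0.257 h, which lies within the scatter of compound 1. Compound 3 `CC(C)C(c1noc(=O)[nH]1)c1ccc(-c2ccc3cccc(F)c3c2)[nH]c1=O` reaches only a limit of the assay, > 3 h. Among the measured compounds shown here, the one measured step, an at least 17-fold higher number from compound 1 to compound 3 (1.24 log units; beyond the scatter), is bounded by that limit (the limit of > 3 h in this assay, at which 1 of the 3 values shown sits).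

Compound 4 `Cc1nc(C(c2ccc(-c3ccc4cccc(F)c4c3)[nH]c2=O)C(C)C)[nH]c1C` differs from compound 1 in one place: 4,5-dimethyl-1H-imidazol-2-yl in place of (1,3-thiazol-2-yl)amino on a saturated chain carbon bound to an aromatic carbon and a saturated chain carbon. For the measured compounds named here, no measured step matches this exchange directly; the step from compound 1 to compound 3 shows that replacing the (1,3-thiazol-2-yl)amino group at this position can lengthen the half-life strongly, so an increase is expected here too, though smaller. Compound 4 is expected to give 0.4 h, between 0.15 h and 1.2 h. This expectation amounts to a 2.4-fold higher number from compound 1 to compound 4 (0.37 log units; beyond the scatter).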

Compound 4, half-life: 0.268 h
Compound 4: the middle estimate sits 1.5-fold (0.17 log units) above what was measured, and the stated range covers the measured number.
By their numbers in this assay, from the lowest: compounds 1, 2 and 4 (each within the scatter of the next). At a limit, above all of these: compound 3.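

In this assay, 4,5-dimethyl-1H-imidazol-2-yl in place of (1,3-thiazol-2-yl)amino on this saturated chain carbon gives a 1.6-fold higher number from compound 1 to compound 4 (0.20 log units; within the scatter), so a new five-membered aromatic ring at this position does not by itself bring a long half-life. The exchange between the groups of compound 3 and compound 4 matters far more, with an at least 11-fold lower number from compound 3 to compound 4 (1.04 log units; beyond the scatter). That step rests on a limit and not on a number: the limit of > 3 h in this assay, at which 1 of the 4 values shown sits.

The compounds shown leave open whether a carboxylic acid or a primary amine on this carbon would give a half-life nearer to that of compound 3 or to that of compound 4.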